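The source may hold more compounds than are shown below. What is called first, only, known or untested is meant among the compounds shown, and "the series" means these compounds.

In a toxicity assay on MT4 cells (Homo sapiens) for cytotoxicity, read by MTT assay, with a stated time of 5 days (a higher number here means that more compound is tolerated, a lower number that less compound is tolerated), compound 3 (`Cc1ccc(-c2cc(C)c(Nc3ccnc(Nc4ccc(C#N)cc4)n3)c(C)c2)s1`) gives 28000 nM. This lies within the scatter of compound 2 (`Cc1csc(-c2cc(C)c(Nc3ccnc(Nc4ccc(C#N)cc4)n3)c(C)c2)c1`), which gives 34000 nM, and far from compound 1 (`Cc1cc(-c2cccc3cc[nH]c23)cc(C)c1Nc1ccnc(Nc2ccc(C#N)cc2)n1`), which gives 1000 nM. Compound 4 (`Cc1cc(-c2cnc(C#N)nc2)cc(C)c1Nc1ccnc(Nc2ccc(C#N)cc2)n1`) carries one change: 2-cyanopyrimidin-5-yl in place of 5-methylthiophen-2-yl on an aromatic carbon, with 2-cyanopyrimidin-5-yl in place of 5-methylthiophen-2-yl. Exchanging one methylthiophene group for the other gave only a 1.2-fold lower number from compound 2 to compound 3 (0.08 log units; within the scatter). Replacing 1H-indol-7-yl at this same place gave a 34-fold higher number from compound 1 to compound 2 (1.53 log units; beyond the scatter) and a 28-fold higher number from compound 1 to compound 3 (1.45 log units; beyond the scatter), so this group can matter greatly. Within the data shown here, no measured compound carries a 2-cyanopyrimidin-5-yl group, so the direction is uncertain. In this assay, the expected change is a modest one, a 2.3-fold lower number from compound 3 to compound 4 (0.37 log units; beyond the scatter). For compound 4, the estimated value is 12000 nM, within an expected range of 3000 nM to 50000 nM.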

Compound 4, half-maximal cytotoxic concentration: 3100 nM
Beside the measured number, compound 4's estimate is 3.9-fold (0.59 log units) above it; the measured number falls inside the stated range.
By their numbers in this assay, from the lowest: compound 1; then compound 4; then compounds 3 and 2 (each within the scatter of the next).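

In this assay, the 2-cyanopyrimidin-5-yl group falls between the earlier groups, with (a 9.0-fold lower number from compound 3 to compound 4 (0.96 log units; beyond the scatter)) and (an 11-fold lower number from compound 2 to compound 4 (1.04 log units; beyond the scatter)) against the two methylthiophene groups, but (a 3.1-fold higher number from compound 1 to compound 4 (0.49 log units; beyond the scatter)) against the indole. This position therefore shifts the number clearly in both directions, and the large gap seen earlier between the indole and the thiophenes can be partly bridged by a third ring type. Nothing here explains these shifts.

Whether the nitrile or the pyrimidine ring drives the change remains open, since the compounds shown offer no plain pyrimidin-5-yl group for comparison. As far as these compounds go, how a ring carrying an amine or a carboxylic acid would behave here is also open.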